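Changing the aryl group on the nitrogen of compound 2

The source may hold more compounds than are shown below. What is called first, only, known or untested is meant among the compounds shown, and "the series" means these compounds.

In a functional assay on MCF7 cells (Homo sapiens) for antiproliferative activity, with a stated time of 72 h (on this read-out higher numbers stand for weaker inhibition and lower numbers for stronger inhibition), compound 1 `CC(=O)Oc1ccccc1/C=C/c1nc2ccccc2c(=O)[nH]1` returns a limit of the assay (> 25000 nM) and not a number. Compound 2 `CC(=O)Oc1ccccc1/C=C/c1nc(Nc2ccccc2I)c2ccccc2n1` gives 15600 nM in this assay and so holds the higher of the two true numbers. Compound 3 `CC(=O)Oc1cccc(/C=C/c2nc3ccccc3c(=O)[nH]2)c1` gives 6370 nM on the same read-out, a lower number by a gap beyond the scatter, and it is the nearest neighbour of compound 2.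

Compound 4 `COc1ccc(OC)c(Nc2nc(/C=C/c3ccccc3OC(C)=O)nc3ccccc23)c1` has not yet been measured. It carries 2,5-dimethoxyphenyl in place of 2-iodophenyl on a nitrogen on an aromatic ring and is otherwise the same as compound 2. Going by the values given here, no measured pair isolates this change, so only a cautious forecast is possible. With compound 2 at 15600 nM as the starting point, a small move toward stronger inhibition, about the size of the scatter, is expected. The expected step of a 1.7-fold lower number from compound 2 to compound 4 (0.24 log units; within the scatter) is therefore modest. Compound 4 is estimated at 9000 nM in this assay (expected range 2500 nM to 25000 nM).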

Compound 4, half-maximal inhibitory concentration: 7840 nM
The estimate for compound 4 lay 1.1-fold (0.06 log units) above the measured number; the range from low to high includes it.
By their numbers in this assay, from the lowest: compounds 3, 4 and 2 (each within the scatter of the next, the first and the last beyond it). At a limit, above all of these: compound 1.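

In this assay, 2,5-dimethoxyphenyl in place of 2-iodophenyl on a nitrogen on an aromatic ring gives a 2.0-fold lower number from compound 2 to compound 4 (0.30 log units; within the scatter), the first step among these compounds that isolates a single change at this position. The entering group has 10 heavy atoms and 2 hydrogen-bond acceptors, the leaving group 7 heavy atoms and 0 acceptors, yet compound 2 and compound 4 cannot be told apart on this read-out. Nothing in the data shown explains this result.

The compounds shown leave open whether either methoxy group alone would read the same as the pair in compound 4. They also leave open how an unsubstituted phenyl, a cyclohexyl or an aryl group bearing a carboxylic acid would read on the same nitrogen.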